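The compounds below may be only part of what the source reports. "The series", "measured", "known", "first", "only" and "open" are said of these compounds alone.

In a functional assay on MCF7 cells (Homo sapiens) for antiproliferative activity, read by MTT assay, with a stated time of 48 h (a lower number here means a stronger inhibitor, a higher number a weaker inhibitor), compound 1 `O=C(NS(=O)(=O)c1ccc(Br)cc1)c1cccnc1Cl` gives 11400 nM and compound 2 `Cc1ccc(S(=O)(=O)NC(=O)c2ccc(C)nc2Cl)cc1` gives 8520 nM so the two values lie within the usual scatter of each other. Compound 3 `Cc1ccc(C(=O)NS(=O)(=O)c2ccc(Br)cc2)c(Cl)n1` has not yet been measured. It differs from compound 2 by a single swap on the ring: bromo in place of methyl on an aromatic carbon with bromo in place of methyl on an aromatic carbon. Within the data shown here, no measured step yet shows what this swap does, so no step beyond the scatter is expected in this assay and the estimated move is small: a 1.1-fold higher number from compound 2 to compound 3 (0.02 log units; within the scatter) in all. The expected value for compound 3 is 9000 nM with an estimated range from 4500 nM to 18000 nM for now.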

Compound 3, half-maximal inhibitory concentration: 1970 nM
Beside the measured number, compound 3's estimate is 4.6-fold (0.66 log units) above it; the whole stated range lies above it.
By their numbers in this assay, from the lowest: compound 3; then compounds 2 and 1 (each within the scatter of the next).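

In this assay, the aromatic carbon para to a large group proves sensitive: bromo in place of methyl there gives a 4.3-fold lower number from compound 2 to compound 3 (0.64 log units; beyond the scatter) on this position alone. A second change also counts, since methyl in place of hydrogen on an aromatic carbon gives a 5.8-fold lower number from compound 1 to compound 3 (0.76 log units; beyond the scatter) and the close values of compound 1 and compound 2, which differ in both places, had hidden both effects. Nothing measured here explains either step. As far as these compounds go, whether a fluoro, a methoxy or an amine on that same carbon would lower the number further stays open. So does the effect of a longer chain in place of the added methyl.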